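Swapping sulfur for selenium on a shared amidine core

The source may report more compounds than this note shows. Statements on the series, on what has been measured and on what is new or still open speak of the compounds shown alone.

Compound 2 `CS/C(=N\C(=O)c1cc(-c2ccccc2)nc2ccccc12)NC(=O)c1cc(-c2ccccc2)nc2ccccc12` is one of a small set of closely related compounds tested in a functional assay on HepG2 cells (Homo sapiens) for cytotoxicity, read by MTT assay, with a stated time of 72 h; a higher number here means that more compound is tolerated, a lower number that less compound is tolerated. In this assay compound 2 reaches only the limit of the measurement, > 100000 nM, so no exact number is known for it. Compound 1 `O=C(/N=C(/NC(=O)c1cc(-c2ccccc2)nc2ccccc12)[Se]Cc1ccccc1)c1cc(-c2ccccc2)nc2ccccc12`, which carries a larger benzyl-bearing selenium group in the same place, gives 78900 nM. The step from that compound to compound 2 is an at least 1.2-fold higher number from compound 1 to compound 2 (0.10 log units; that floor lies within the scatter), and it cannot be sized properly because of the limit of > 100000 nM in this assay, at which 1 of the 2 values shown sits. Compound 3 `C[Se]/C(=N\C(=O)c1cc(-c2ccccc2)nc2ccccc12)NC(=O)c1cc(-c2ccccc2)nc2ccccc12` is compound 2 with a small change: a group of 2 heavy atoms (1 carbon, 1 selenium; no ring) in place of a group of 2 heavy atoms (1 carbon, 1 sulfur; no ring), on a carbon with a double bond to nitrogen. For the measured compounds named here, the only measured step that touches this position also exchanged sulfur for selenium, but together with a much larger group, so it gives weak guidance. The step from compound 2 to compound 3 is therefore expected to be roughly an at least 1.2-fold lower number from compound 2 to compound 3 (0.09 log units; that floor lies within the scatter), likely small. Compound 3 is estimated at 80000 nM, with a plausible range from 35000 nM to 200000 nM.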

Compound 3, concentration lethal to 50% of the cells: 65400 nM
Compound 3: the middle estimate sits 1.2-fold (0.09 log units) above what was measured, within the range that was stated.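

The result separates the two changes that were mixed in the earlier step. With selenium kept, hydrogen in place of phenyl on the saturated chain carbon bound to selenium yields a 1.2-fold lower number from compound 1 to compound 3 (0.08 log units; within the scatter) in this assay, so this part of the change has no readable effect here. The exchange of sulfur for selenium on its own yields an at least 1.5-fold lower number from compound 2 to compound 3 (0.18 log units; that floor lies within the scatter), and its true size cannot be read because compound 2 stands at a limit: the limit of > 100000 nM in this assay, at which 1 of the 3 values shown sits.

The compounds shown leave open whether an amine or a longer chain such as ethylsulfanyl, on the carbon with a double bond to nitrogen, would change how much compound the cells tolerate. They also leave open where a methoxy group at that place would fall.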